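Compound 1 to compound 4: a step at the limit

The source may hold more compounds than are shown below. What is called first, only, known or untested is meant among the compounds shown, and "the series" means these compounds.

In an ADME assay on WI-38 cells (Homo sapiens) for cytotoxicity, read by MTT assay, with a stated time of 48 h (on this read-out lower numbers stand for stronger inhibition and higher numbers for weaker inhibition), compound 1 (`O=C(CCCCC1CCSS1)OCCCOC(=O)c1cccnc1`) gives > 800000 nM as a limit and not a number. Compound 2 (`Cc1ccc(NC(=S)OCCNC(=O)C(C)(C)Oc2ccc(Cl)cc2)cc1`) gives > 800000 nM as a limit as well. Compound 3 (`CC(C)(Oc1ccc(Cl)cc1)C(=O)NCCOC(=S)Nc1ccc([N+](=O)[O-])cc1Cl`) gives > 800000 nM as a limit too. The evidence is the limit of > 800000 nM in this assay, at which 3 of the 3 values shown sit, and nothing finer. Among the measured compounds shown here, the single measured step is a step that the two limits leave unreadable from compound 2 to compound 3 and gives no size to carry over. For the measured compounds named here, compound 4 (`Cc1cnc(C(=O)OCCCOC(=O)CCCCC2CCSS2)c[n+]1[O-]`) differs from compound 1 by a group of 8 heavy atoms (5 carbon, 2 nitrogen, 1 oxygen; one six-membered aromatic ring with 2 hetero atoms) in place of a group of 6 heavy atoms (5 carbon, 1 nitrogen; one six-membered aromatic ring with 1 hetero atom), on a carbonyl carbon and no measured step covers that change. Starting from compound 1 at > 800000 nM as a limit, no step beyond the scatter is expected in this assay and no direction can be given. The expected change is a number no higher from compound 1 to compound 4 (the limit leaves the size open) by this estimate. Compound 4 is expected at 800000 nM with an estimated range of 300000 nM to 1600000 nM in this assay.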

Compound 4, half-maximal inhibitory concentration: > 800000 nM
Compound 4: no number, only a limit; the forecaster's own chance of this, stated with the estimate: 85%; the middle value lies on the limit itself.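

Compound 1 and compound 4 both give limits, not numbers, in this assay, and no new step can be read between them. The compounds shown leave open how any of them would rank in this assay.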